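A methyl on the amine of compound 3

The compounds below may be only part of what the source reports. "The series", "measured", "known", "first", "only" and "open" are said of these compounds alone.

Compound 3 (`CC[C@H](N)C(=O)N[C@@H]1C(=O)N2[C@@H](CC[C@@H]1CCNC(=O)c1ccccc1)CC[C@H]2C(=O)NC(c1ccccc1)c1ccccc1`) gives 50700 nM in a functional assay on HL-60 cells (Homo sapiens) for cytotoxicity, read by MTT assay, with a stated time of 96 h (a lower number here means a stronger inhibitor, a higher number a weaker inhibitor), and lies within the usual scatter of the other two measured compounds, compound 1 (`CC[C@H](NC)C(=O)N[C@@H]1C(=O)N2[C@@H](CC[C@@H]1CN)CC[C@H]2C(=O)NC(c1ccccc1)c1ccccc1`) at 51800 nM and compound 2 (`CC[C@H](NC)C(=O)N[C@@H]1C(=O)N2[C@@H](CC[C@@H]1CCN)CC[C@H]2C(=O)NC(c1ccccc1)c1ccccc1`) at 31000 nM in the same test. Compound 4 (`CC[C@H](NC)C(=O)N[C@@H]1C(=O)N2[C@@H](CC[C@@H]1CCNC(=O)c1ccccc1)CC[C@H]2C(=O)NC(c1ccccc1)c1ccccc1`) carries methyl in place of hydrogen on an amine nitrogen and so turns amino to methylamino. Within the data shown here, no measured step isolates this change. Among the measured compounds shown here, the single step available (a 1.7-fold lower number from compound 1 to compound 2 (0.22 log units; within the scatter)) concerns aminomethyl in place of amino, so it bears only indirectly. Compound 1 and compound 2 already carry methylamino, yet their values stay within the scatter of compound 3. No step beyond the scatter is expected, in either direction. The estimate amounts to a 1.1-fold lower number from compound 3 to compound 4 (0.05 log units; within the scatter) and nothing larger is expected. Compound 4 is expected at 45000 nM in this assay (estimated range 20000 nM to 100000 nM).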

Compound 4, half-maximal inhibitory concentration: 32600 nM
Compound 4: the middle estimate sits 1.4-fold (0.14 log units) above what was measured; the range from low to high includes it.
By their numbers in this assay, from the lowest: compounds 2, 4, 3 and 1 (each within the scatter of the next).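

In this assay, among these compounds, methyl in place of hydrogen on the amine nitrogen gives a 1.6-fold lower number from compound 3 to compound 4 (0.19 log units; within the scatter) and so provides the first direct reading of this change, which stays within the scatter. With methylamino present, adding benzoyl gives a 1.1-fold higher number from compound 2 to compound 4 (0.02 log units; within the scatter) and benzamidomethyl in place of amino gives a 1.6-fold lower number from compound 1 to compound 4 (0.20 log units; within the scatter) and neither step leaves the scatter. Nothing available explains these values.

On these data alone, whether ethyl or acetyl on this amine nitrogen would also stay within the scatter remains open.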